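The compounds below may be only part of what the source reports. "The series", "measured", "known", "first", "only" and "open" are said of these compounds alone.

Series notes. Compound 1 `O=C(c1ccc(F)cc1)N1CCc2nc(COc3cccc(F)c3)oc2C1` gives 78% in a functional assay on HEK293 cells for positive allosteric modulation of metabotropic glutamate receptor 5 (Homo sapiens), read by calcium flux; a lower number here means a smaller maximal response, a higher number a larger maximal response. For the measured compounds named here, compound 2 `O=C(c1ccc(F)cc1)N1CCc2nc(COc3cccnc3)oc2C1` gives 40% in this assay, the lowest of the two numbers so far; the step of a number 38 percentage points lower from compound 1 to compound 2 (beyond the scatter) lies beyond the scatter. Compound 3 `O=C(c1ccc(F)cc1)N1CCc2nc(COc3ccncc3)oc2C1` is not yet measured; relative to compound 2 the change is pyridin-4-yl in place of pyridin-3-yl on an oxygen on a saturated carbon. Going by the values given here, no measured step covers this exchange; the only step, a number 38 percentage points lower from compound 1 to compound 2 (beyond the scatter), concerns a different group at that place and shows only that exchange there can move the response strongly. The expected step is a number 2 percentage points higher from compound 2 to compound 3 (within the scatter), within the scatter in either direction. Compound 3 is estimated at 42%, range 25% to 65%.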

Compound 3, largest response reached (reported as percent of maximum), in percent of the reference or control that the assay uses: 71%
Beside the measured number, compound 3's estimate is 29 percentage points below it; the whole stated range lies below it.
By their numbers in this assay, from the lowest: compound 2; then compounds 3 and 1 (each within the scatter of the next).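

In this assay the two pyridines are not interchangeable on this oxygen: the exchange of pyridin-3-yl for pyridin-4-yl, with the same atoms joined differently, gives a number 31 percentage points higher from compound 2 to compound 3 (beyond the scatter). The low response of compound 2 therefore does not extend to every pyridine here, and 3-fluorophenyl to pyridin-4-yl gives a number 7 percentage points lower from compound 1 to compound 3 (within the scatter). Nothing measured here accounts for the gap between the two pyridines. Still open, on these data alone, is how pyridin-2-yl on the same oxygen would respond, and whether a substituent such as an amine on the pyridin-4-yl ring keeps this response.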